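The source may report more compounds than this note shows. Statements on the series, on what has been measured and on what is new or still open speak of the compounds shown alone.

In a functional assay on SF-295 cells (Homo sapiens) for cytotoxicity (on this read-out higher numbers stand for weaker inhibition of growth and lower numbers for stronger inhibition of growth), compound 2 `OCCCCC#Cc1ccccc1C#Cc1ccccn1` gives 21800 nM, and compound 1 `OCC#Cc1ccccc1C#Cc1ccccc1` gives 20600 nM; these two numbers sit within the usual scatter of each other, so neither can be called different from the other. Compound 3 `OCCCCC#Cc1ccccc1C#Cc1cccc(O)c1` has not yet been measured in this assay. It differs from compound 2 in one place: 3-hydroxyphenyl in place of pyridin-2-yl on a triple-bonded carbon. For the measured compounds named here, no measured pair shows this kind of exchange, so there is no step to lean on. The step of a 1.1-fold lower number from compound 2 to compound 3 (0.04 log units; within the scatter) is therefore expected to stay within the scatter, in no particular direction. Compound 3 is estimated at 20000 nM, with a range from 8000 nM to 50000 nM.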

Compound 3, concentration for 50% growth inhibition: 21000 nM
Compound 3: middle estimate off by 1.1-fold (0.02 log units), on the low side; low and high end bracket the measured number.
By their numbers in this assay, from the lowest: compounds 1, 3 and 2 (each within the scatter of the next).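

In this assay, for the compounds shown here, 3-hydroxyphenyl in place of pyridin-2-yl on a triple-bonded carbon gives a 1.0-fold lower number from compound 2 to compound 3 (0.02 log units; within the scatter), the only measured exchange at this place. The entering group brings a hydrogen-bond donor and a ring of carbon only, yet the read-out shows no difference beyond the scatter. Nothing available explains this result. As far as these compounds go, whether an amine or a carboxylic acid at this place would move the number beyond the scatter remains open. So does the effect of a longer chain on the other triple bond.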